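The source may hold more compounds than are shown below. What is called first, only, known or untested is meant among the compounds shown, and "the series" means these compounds.

Measured so far in an assay on isolated protein for binding affinity to B1 bradykinin receptor (Homo sapiens); a higher number here means a weaker inhibitor, a lower number a stronger inhibitor:
compound 1 `COC(=O)N1CCCCC1c1ccc(CNc2nccc(C)c2NC(=O)CC#N)cc1`: > 5000 nM
compound 2 `COC(=O)c1ccccc1N1CCC(C)(CNc2nccc(C)c2NC(=O)CC#N)CC1`: 3500 nM
compound 3 `COC(=O)c1ccccc1C1CCC(CNc2nccc(C)c2NC(=O)CC#N)CC1`: 385 nM

The entry for compound 1 is a limit of this assay and not a number (the limit of > 5000 nM in this assay, at which 1 of the 3 values shown sits). Compound 1 therefore stands at the weak end of the three results; compound 2 and compound 3 give numbers, and compound 3 sits clearly lower than compound 2.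

Compound 4 `COC(=O)C1CCCCC1c1ccc(CNc2nccc(C)c2NC(=O)CC#N)cc1` differs from compound 1 in one place: 2-(methoxycarbonyl)cyclohexyl in place of 1-(methoxycarbonyl)piperidin-2-yl on an aromatic carbon. Within the data shown here, no measured pair covers this change, so the direction is open. The ring of compound 4 is a cyclohexyl, as in compound 3, while compound 1 carries a piperidine, as does compound 2, but those two pairs differ elsewhere as well.

Compound 4 is expected near 3500 nM, within 900 nM to 15000 nM. The expected step of an at least 1.4-fold lower number from compound 1 to compound 4 (0.15 log units; that floor lies within the scatter) is modest, with a chance of another limit.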

Compound 4, inhibition constant: 2.2 nM
Compound 4: the middle estimate sits 1600-fold (3.20 log units) above what was measured, and the stated range ends above it.
By their numbers in this assay, from the lowest: compound 4; then compound 3; then compound 2. At a limit, above all of these: compound 1.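

In this assay, 2-(methoxycarbonyl)cyclohexyl in place of 1-(methoxycarbonyl)piperidin-2-yl on an aromatic carbon gives an at least 2200-fold lower number from compound 1 to compound 4 (3.35 log units; beyond the scatter). The entry for compound 1 is a limit of the assay and not a number: the limit of > 5000 nM in this assay, at which 1 of the 4 values shown sits. This one-place pair, the first in the series, shows that this position is highly sensitive to the ring, even though the two groups match in heavy-atom count and hydrogen-bond acceptors.

The pair does not separate losing the ring nitrogen from moving the methoxycarbonyl from nitrogen to carbon. Going by these compounds, a carboxylic acid or primary amide in place of the methyl ester, or an unsubstituted cyclohexyl, remains open.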